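This account rests on a few compounds, and the source may have more. Where it says the series, first, only, none or still open, it means among the compounds named here.

Of the compounds shown here, two from the series have been measured in a functional assay on DU-145 cells (Homo sapiens) for cytotoxicity, read by sulforhodamine B assay, with a stated time of 48 h, tested at 100 nM; a higher number here means a weaker effect of the compound at the concentration tested, a lower number a stronger effect. Compound 1 `COc1cc(C)cc(-c2c(-c3ccnc(-c4ccc(C(C)=O)cc4)c3)cnn2CC#N)c1` gives 89%, and compound 2 `Cc1cc(O)cc(-c2nn(CC#N)cc2-c2ccnc(-c3ccc(Oc4ccccc4)cc3)c2)c1` gives 86%, a number that lies within the scatter of compound 1, so the two are not separated by this assay. Compound 3 `Cc1cc(O)cc(-c2nn(CC#N)cc2-c2ccnc(-c3ccc(N(C)C)cc3)c2)c1` differs from compound 2 in one place: dimethylamino in place of phenoxy on an aromatic carbon. Within the data shown here, no measured pair shows this change, so the step from compound 2 to compound 3 in this assay is expected to be small, a number 1 percentage points lower from compound 2 to compound 3 (within the scatter), not beyond the scatter. Compound 3 is therefore estimated at 85%, in the range 65% to 100%.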

Compound 3, a percentage reported as activity, at one concentration (the size of the read-out at that concentration, not a potency): 94%
The estimate for compound 3 lay 9 percentage points below the measured number; measured number inside the range.
By their numbers in this assay, from the lowest: compounds 2, 1 and 3 (each within the scatter of the next).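

In this assay, putting dimethylamino in place of phenoxy, para to a large group, gives a number 8 percentage points higher from compound 2 to compound 3 (within the scatter), so this first comparison at this position does not separate the two groups, although the change removes a six-membered aromatic ring of carbon only. Nothing available here accounts for this result. On these data alone, what stays open is whether a carboxylic acid, a primary amine or a single fluorine on this aromatic carbon would give a step beyond the scatter. As far as these compounds go, whether the acetyl group of compound 1 belongs with these groups also remains open, since compound 1 differs from compound 2 in more than one place.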